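Moving One Methyl on the Amide Aryl Group

This account rests on a few compounds, and the source may have more. Where it says the series, first, only, none or still open, it means among the compounds named here.

Measured compounds:
compound 1 `COc1ccc2nc(C)cc(OCC(=O)Nc3cc(C)cc(C)c3)c2c1`: 20000 nM
compound 2 `COc1ccc2nc(C)cc(OCC(=O)NCc3cc(C)cc(C)c3)c2c1`: > 100000 nM
compound 3 `COc1ccc2nc(C)cc(OCC(=O)Nc3cc(C)ccc3C)c2c1`: > 100000 nM

In a toxicity assay on HepG2 cells (Homo sapiens) for inhibition, read by CellTiter-Glo, with a stated time of 48 h (on this read-out higher numbers stand for weaker inhibition and lower numbers for stronger inhibition), compound 1 gives 20000 nM. For compound 2 the value > 100000 nM is a limit of the assay and not a number. For compound 3 the value > 100000 nM is likewise a limit. Compound 3 therefore stands at the limit of > 100000 nM in this assay, at which 2 of the 3 values shown sit, and its position among the measured compounds is known only as a limit.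

Compound 4 `COc1ccc2nc(C)cc(OCC(=O)Nc3c(C)cccc3C)c2c1` differs from compound 3 in one place: 2,6-dimethylphenyl in place of 2,5-dimethylphenyl on an amide-type nitrogen. The measured steps that bear on this are an at least 5.0-fold higher number from compound 1 to compound 3 (0.69 log units; beyond the scatter) and an at least 5.0-fold higher number from compound 1 to compound 2 (0.69 log units; beyond the scatter), both changes on the same amide-type nitrogen. The remaining step, a step that the two limits leave unreadable from compound 2 to compound 3, cannot be read because both values are limits. With compound 3 already at the limit, a further rearrangement of the methyl groups is not expected to produce a readable step in this assay. Compound 4 is therefore expected to sit near 100000 nM, within a range of 30000 nM to 300000 nM, which means an expected step of a number no higher from compound 3 to compound 4 (the limit leaves the size open).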

Compound 4, half-maximal inhibitory concentration: > 100000 nM
Compound 4 gave a limit, no number; the forecaster's own chance of this, stated with the estimate: 75%; the middle value sits exactly at the limit.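

In this assay compound 4 gives > 100000 nM, which is a limit of the assay and not a number. On the amide-type nitrogen, 2,6-dimethylphenyl in place of 3,5-dimethylphenyl gives an at least 5.0-fold higher number from compound 1 to compound 4 (0.69 log units; beyond the scatter), so a second rearrangement of the two methyl groups also leaves the read-out without a number, and compound 1 remains the only one of the four that has one: the limit of > 100000 nM in this assay, at which 3 of the 4 values shown sit. The steps among compound 2, compound 3 and compound 4 cannot be read, so 2,6-dimethylphenyl and 2,5-dimethylphenyl cannot be ordered here.

The compounds shown leave open how far apart compound 2, compound 3 and compound 4 really lie. They also leave open whether a plain phenyl group or a morpholine on the same nitrogen would give a readable value in this assay.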